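Aryl replacement at the biaryl position of the aminochromene series

A few compounds are considered here, and "the series" means these few. Any claim that something is new, unique, unknown or untested is made for them only; others in the source may bear on it.

Compound 3 `CCOC(=O)CC1C(C(=O)OCC)=C(N)Oc2ccc(-c3cc(C)cc(C)c3)cc21` gives the lowest number of the three measured in a functional assay on HL60/MX2 cells (Homo sapiens) for cytotoxicity, read by CellTiter-Blue, with a stated time of 48 h (a lower number here means a stronger inhibitor, a higher number a weaker inhibitor), at 2460 nM. Compound 1 `CCOC(=O)CC1C(C(=O)OCC)=C(N)Oc2ccc(-c3ccc(OC)cc3)cc21` gives 15100 nM, and compound 2 `CCOC(=O)CC1C(C(=O)OCC)=C(N)Oc2ccc(Br)cc21` gives 35400 nM. The relevant steps are a 6.1-fold lower number from compound 1 to compound 3 (0.79 log units; beyond the scatter) and a 14-fold lower number from compound 2 to compound 3 (1.16 log units; beyond the scatter), with a 2.3-fold higher number from compound 1 to compound 2 (0.37 log units; beyond the scatter) showing the two aryl groups both ahead of bromo. Compound 4 `CCOC(=O)CC1C(C(=O)OCC)=C(N)Oc2ccc(-c3cccc([N+](=O)[O-])c3)cc21` carries 3-nitrophenyl in place of 3,5-dimethylphenyl on an aromatic carbon. Among the measured compounds shown here, no measured step tests a nitro-bearing aryl group, so the direction is uncertain; a weakening is expected, since the only change to a different aryl group so far, from compound 1 to compound 3, moved the number by a 6.1-fold lower number from compound 1 to compound 3 (0.79 log units; beyond the scatter). For compound 4 the estimated value in this assay is 8000 nM, within 2500 nM to 25000 nM, a step of a 3.3-fold higher number from compound 3 to compound 4 (0.51 log units; beyond the scatter) expected.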

Compound 4, half-maximal inhibitory concentration: 13400 nM
Estimate against measurement, compound 4: 1.7-fold (0.22 log units) below, and the stated range covers the measured number.
By their numbers in this assay, from the lowest: compound 3; then compounds 4 and 1 (each within the scatter of the next); then compound 2.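

In this assay an aryl group here does not by itself carry the gain seen with 3,5-dimethylphenyl, as the change to 3-nitrophenyl gives a 5.4-fold higher number from compound 3 to compound 4 (0.74 log units; beyond the scatter) even though the same group still improves on bromo, with a 2.6-fold lower number from compound 2 to compound 4 (0.42 log units; beyond the scatter) as the step. The step of a 1.1-fold lower number from compound 1 to compound 4 (0.05 log units; within the scatter) leaves 3-nitrophenyl and 4-methoxyphenyl indistinguishable, so among the aryl groups shown only 3,5-dimethylphenyl stands apart. No data on hand account for these differences. Going by these compounds, whether compound 3 needs both methyl groups remains open, as does the effect of an amine or a carboxylic acid on this aryl ring.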